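Cytotoxicity notes: chloro to methyl on the fused ring

The compounds below may be only part of what the source reports. "The series", "measured", "known", "first", "only" and "open" are said of these compounds alone.

Compound 2 `CCN(CC)CN1C(=O)/C(=N\NC(=S)NO)c2cc(Cl)ccc21` sits second highest of the three numbers measured in an ADME assay on MT4 cells (Homo sapiens) for cytotoxicity, read by spectrophotometry, with a stated time of 5 days (a higher number here means that more compound is tolerated, a lower number that less compound is tolerated), where compound 2 gives 562000 nM. Compound 3 `CN(C)CN1C(=O)/C(=N\NC(=S)NO)c2cc(F)ccc21` gives 599000 nM in this assay, within the scatter of compound 2. Compound 1 `COc1ccc(N2CCN(CN3C(=O)/C(=N\NC(=S)NO)c4cc(F)ccc43)CC2)cc1` gives 260000 nM in this assay, a lower number than compound 2 and beyond the scatter. Compound 4 `CCN(CC)CN1C(=O)/C(=N\NC(=S)NO)c2cc(C)ccc21` has not been measured in this assay. It differs from compound 2 by methyl in place of chloro on an aromatic carbon. Within the data shown here, no measured pair here shows the effect of such an exchange, so no direction can be read from the series. The expectation is a step no larger than the scatter from compound 2 to compound 4, a 1.0-fold lower number from compound 2 to compound 4 (0.01 log units; within the scatter). Compound 4 is therefore estimated at 550000 nM in this assay, with a range from 250000 nM to 1000000 nM.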

Compound 4, half-maximal cytotoxic concentration: 534000 nM
The estimate for compound 4 lay 1.0-fold (0.01 log units) above the measured number, within the range that was stated.
By their numbers in this assay, from the lowest: compound 1; then compounds 4, 2 and 3 (each within the scatter of the next).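

Methyl in place of chloro on this aromatic carbon gives a 1.1-fold lower number from compound 2 to compound 4 (0.02 log units; within the scatter) in this assay and is the only one-place step shown. At this position, with the side chain of compound 2 held fixed, the exchange leaves the number within the scatter, so chloro and methyl are not told apart here. Nothing measured bears on why this exchange leaves the number in place. Still open, as far as these compounds go, is whether a carboxylic acid or an amine on this aromatic carbon would also stay within the scatter. Also open, from the compounds shown here alone, is whether methyl and chloro remain indistinguishable with the 4-methoxyphenyl piperazine side chain of compound 1 in place.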